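Hydroxamate to aminoanilide swap on the benzylamine series

This account rests on a few compounds, and the source may have more. Where it says the series, first, only, none or still open, it means among the compounds named here.

Measured so far:
compound 1, `Nc1ccccc1NC(=O)c1ccc(CNC2=N[C@@H](Cc3ccccc3)CS2)cc1`: > 20000 nM
compound 2, `O=C(NO)c1ccc(CNc2nccc(-c3cccnc3)n2)cc1`: 42 nM

Among the measured compounds shown here, in an assay on isolated protein for inhibition of protein deacetylase HDAC6 (Homo sapiens), read by fluorescence, with stated times of 3 h and 60 min (on this read-out higher numbers stand for weaker inhibition and lower numbers for stronger inhibition), compound 2 gives 42 nM, the only number in the set so far. Compound 1 returns > 20000 nM, which is a limit of the assay and not a number. That limit is the situation summarised by the limit of > 20000 nM in this assay, at which 1 of the 2 values shown sits. For the measured compounds named here, compound 2 therefore stands alone as the one compound with a measured inhibitory concentration.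

Compound 3, `COc1ccc(NC(=O)c2ccc(CNc3nccc(-c4cccnc4)n3)cc2)c(N)c1`, is not yet measured. Its change from compound 2 is 2-amino-4-methoxyphenyl in place of hydroxy on an amide-type nitrogen. Going by the values given here, no pair of measured compounds differing in one place is available, so the size of this step cannot be read off from the data. The closest point of reference is compound 1, the other amide in the set, and compound 1 gives only the limit > 20000 nM in this assay. On that basis the step from the hydroxamic acid to the anilide is expected to reach well beyond the scatter, toward weaker inhibition. The estimate for compound 3 is 15000 nM, within a range from 3000 nM to 60000 nM. The expected step is a 360-fold higher number from compound 2 to compound 3 (2.55 log units; beyond the scatter), with a fair chance that the assay reports only a limit for compound 3.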

Compound 3, half-maximal inhibitory concentration: > 20000 nM
Compound 3 gave a limit, no number (the forecaster's own chance of this, stated with the estimate: 55%); middle value at least 1.3-fold (0.12 log units) away from the limit.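

Among the compounds shown here, on the shared core, 2-amino-4-methoxyphenyl in place of hydroxy on an amide-type nitrogen gives an at least 470-fold higher number from compound 2 to compound 3 (2.67 log units; beyond the scatter) in this assay, and this is the first one-place change that can be read, so the loss of measurable inhibition can now be tied to this single position rather than only inferred from a compound with a different core. For compound 3, > 20000 nM is a limit of the assay and not a number. On this core the hydroxamic acid therefore remains the only form with a measured inhibitory concentration, and the anilide form joins compound 1 at the same limit: the limit of > 20000 nM in this assay, at which 2 of the 3 values shown sit.

How far past the limit compound 3 lies cannot be read, and neither can any step to or from compound 1, which differs from the others in more than one place. The data do not separate the loss of hydroxy from the arrival of the amino and methoxy groups of the new ring. A methoxy or an unsubstituted phenyl on the same amide-type nitrogen, measured in this assay, would help to separate them.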